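Chloro for Cyano in a Nitroaryl Biphenyl Alcohol Series

A few compounds are considered here, and "the series" means these few. Any claim that something is new, unique, unknown or untested is made for them only; others in the source may bear on it.

Measured so far:
compound 1, `COc1cc(CC(O)c2ccc(-c3cccc(C#N)c3)cc2)c([N+](=O)[O-])cc1OC`: 5200 nM
compound 2, `COc1cc(CC(O)c2ccc(-c3cccc(Cl)c3)cc2)c([N+](=O)[O-])cc1OC`: 5900 nM
compound 3, `COc1cc(CC(O)c2cccc(-c3ccc(C#N)cc3)c2)c([N+](=O)[O-])cc1OC`: 9300 nM

These three compounds were tested in an ADME assay on HeLa Rh cells (Homo sapiens) for cytotoxicity, read by microscopy; on this read-out lower numbers stand for higher toxicity in this test and higher numbers for lower toxicity in this test. Compound 1 and compound 2 share a core and differ by chloro in place of cyano on an aromatic carbon; in this assay that change gave a 1.1-fold higher number from compound 1 to compound 2 (0.05 log units; within the scatter). Compound 3 has the same atoms as compound 1 joined differently; the difference between the two cores is not broken down here, and the gap between compound 3 and compound 2 or compound 1 stays within the scatter.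

Compound 4, `COc1cc(CC(O)c2cccc(-c3ccc(Cl)cc3)c2)c([N+](=O)[O-])cc1OC`, has not yet been measured. It differs from compound 3 by chloro in place of cyano on an aromatic carbon. For the measured compounds named here, this is the same kind of change as the one from compound 1 to compound 2, not the same: there the group sits meta to a large group, here para to a large group.

For compound 4 in this assay the expected step is a 1.1-fold higher number from compound 3 to compound 4 (0.03 log units; within the scatter), because the earlier step of a 1.1-fold higher number from compound 1 to compound 2 (0.05 log units; within the scatter) hardly moved the number. Compound 4 is thus estimated at 10000 nM, with a likely range from 5000 nM to 20000 nM.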

Compound 4, half-maximal cytotoxic concentration: 5000 nM
Estimate against measurement, compound 4: 2.0-fold (0.30 log units) above; the measured number falls inside the stated range.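

In this assay, chloro in place of cyano on the core of compound 3 gave a 1.9-fold lower number from compound 3 to compound 4 (0.27 log units; within the scatter). Set beside the earlier case, the two outcomes cannot be told apart: the same change on two cores in this assay, a 1.1-fold higher number (0.05 log units; within the scatter) from compound 1 to compound 2 and a 1.9-fold lower number (0.27 log units; within the scatter) from compound 3 to compound 4, 2.1-fold (0.32 log units) apart, within the scatter of two such steps. On these two cores the change therefore left the number within the scatter each time, and nothing here shows that the core alters its outcome, but two pairs do not show that it would behave the same way on a further core, nor can they rule out a small real difference hidden by the scatter.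

The compounds shown carry only cyano or chloro at this place, so it remains open how a carboxylic acid, an amine or a longer chain there would read in this assay. All four compounds also keep the nitro group and the alcohol, which leaves open what an amine in place of the nitro group or a ketone in place of the alcohol would do.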